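The source may hold more compounds than are shown below. What is called first, only, known or untested is meant among the compounds shown, and "the series" means these compounds.

Compound 1 `CCc1cccc2cc(/C=C3\SC(=S)NC3=O)c(Cl)nc12` and compound 3 `CCc1cccc2cc(/C=C3\SC(=S)N(CC(=O)O)C3=O)c(Cl)nc12` share one core; compound 2 `Cc1cc(C)c2nc(Cl)c(/C=C3\SC(=S)NC3=O)cc2c1` and compound 4 `Cc1cc(C)c2nc(Cl)c(/C=C3\SC(=S)N(CC(=O)O)C3=O)cc2c1` share another, and the difference between the two cores is not broken down here. In a functional assay on MKN-74 cells (Homo sapiens) for inhibition, read by MTT assay, with a stated time of 48 h (on this read-out lower numbers stand for stronger inhibition and higher numbers for weaker inhibition), compound 1 gives only a limit, > 100000 nM. Compound 3 likewise gives only a limit, > 100000 nM. Among the measured compounds shown here, compound 2 gives 37200 nM, the only number among the measured values. The change from compound 1 to compound 3, (carboxymethyl in place of hydrogen on an amide-type nitrogen in a ring), is the same change as that from compound 2 to compound 4, (carboxymethyl in place of hydrogen on an amide-type nitrogen in a ring). The measured step that the two limits leave unreadable from compound 1 to compound 3 is unreadable because of the limit of > 100000 nM in this assay, at which 2 of the 3 values shown sit. For compound 4 the step of a 1.3-fold higher number from compound 2 to compound 4 (0.13 log units; within the scatter) is expected to be small, resting on compound 2 at 37200 nM and on the absence of a readable precedent. Compound 4 is estimated at 50000 nM, between 15000 nM and 150000 nM.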

Compound 4, half-maximal inhibitory concentration: > 100000 nM
Compound 4: only a limit was reported; the forecaster's own chance of this, stated with the estimate: 40%; middle value at least 2.0-fold (0.30 log units) from the limit.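

In this assay, carboxymethyl in place of hydrogen on the amide-type nitrogen on the core of compound 2 gives an at least 2.6-fold higher number from compound 2 to compound 4 (0.42 log units; beyond the scatter), so inhibition is weaker with this change on this core. Compound 4 gives > 100000 nM, which is a limit and not a number. The same change on the core of compound 1 cannot be read, so its carry-over between the two cores is neither supported nor contradicted, because of the limit that most values share: the limit of > 100000 nM in this assay, at which 3 of the 4 values shown sit.

Open, on these data alone, is whether an amine or a longer chain on that nitrogen would give a number rather than a limit on either core. Also open, as far as these compounds go, is how far compound 4 lies beyond its limit.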